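A few compounds are considered here, and "the series" means these few. Any claim that something is new, unique, unknown or untested is made for them only; others in the source may bear on it.

Going by the values given here, compound 1 `Cc1c(CCCC(=O)O)c2cccc(/C=C/c3ccc(OCCCCc4ccccc4)cc3)c2n1CC(=O)O` is one of two compounds measured in a functional assay on CHO-K1 cells for antagonist activity at cysteinyl leukotriene receptor 1 (Homo sapiens), read by fluorescence and calcium flux, with stated times of 30 min and 1 h; a lower number here means a stronger inhibitor, a higher number a weaker inhibitor. In this assay compound 1 gives 4.1 nM, the lower of the two numbers recorded. The other compound, compound 2 `Cc1c(Cl)cccc1CCCCOc1ccc(C#Cc2cccc3c(CCC(=O)O)c(C)n(CCCCC(=O)O)c23)cc1`, gives 25 nM in this assay; the two structures differ in several places at once, so only the two values themselves can be compared.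

The compound not yet measured is compound 3 `Cc1c(CCCC(=O)O)c2cccc(/C=C/c3ccc(OCCCCc4c(F)cc(F)c(F)c4F)cc3)c2n1CC(=O)O`. It keeps the core of compound 1 and differs from it in one place: 2,3,4,6-tetrafluorophenyl in place of phenyl on a saturated chain carbon, four bonds along the chain from an oxygen on an aromatic ring.

Among the compounds with values here, no measured pair shows the effect of this change, so the expectation rests on compound 1 alone. For compound 3 the author expects a step of a 1.2-fold higher number from compound 1 to compound 3 (0.09 log units; within the scatter), that is, a shift that stays within the usual scatter rather than a clear move in either direction. Compound 3 is therefore estimated to give 5 nM in this assay, with a range from 1.5 nM to 16 nM.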

Compound 3, half-maximal inhibitory concentration in the cysteinyl leukotriene receptor 1 assay: 1.6 nM
Compound 3: middle estimate off by 3.1-fold (0.49 log units), on the high side, and the stated range covers the measured number.
By their numbers in the cysteinyl leukotriene receptor 1 assay, from the lowest: compound 3; then compound 1; then compound 2.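

In the cysteinyl leukotriene receptor 1 assay, the change shows that this end of the chain accepts 2,3,4,6-tetrafluorophenyl in place of phenyl without loss, and in fact gains: a 2.6-fold lower number from compound 1 to compound 3 (0.41 log units; beyond the scatter). In a physicochemical assay for permeability, using PAMPA, with a stated time of 4 h, at pH 7.4, tested at 50 uM (a higher number here means that the compound crosses the layer faster, a lower number that the compound crosses the layer more slowly), compound 3 gives 0.3 10^-6 cm/s, and the same change carries an at least 6.0-fold higher number from compound 1 to compound 3 (0.77 log units; beyond the scatter). In the physicochemical assay compound 1 gives < 0.05 10^-6 cm/s, a limit of the assay and not a number, so that step is only a floor because of this limit: the limit of < 0.05 10^-6 cm/s in the physicochemical assay, at which 1 of the 2 values shown sits.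

The compounds shown leave open whether all four fluorine atoms are needed, or whether a single fluorine or a chlorine on the phenyl ring would give the same result. They also leave open whether the tetrafluorophenyl group would act alike on a shorter chain or on the core of compound 2.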